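This account rests on a few compounds, and the source may have more. Where it says the series, first, only, none or still open, it means among the compounds named here.

Compound 1 `CCCCOc1c(-c2cc(OC)c(OC)c(OC)c2)oc2ccccc2c1=O`: > 50000 nM, a limit
Compound 2 `CCC(C)Oc1c(-c2cc(OC)c(OC)c(OC)c2)oc2ccccc2c1=O`: > 50000 nM, a limit
Compound 3 `CCN(CC)CCCCCOc1c(-c2cc(OC)c(OC)c(OC)c2)oc2ccccc2c1=O`: 33400 nM

Within the data shown here, in a functional assay on DU-145 cells (Homo sapiens) for antiproliferative activity, read by WST assay, with a stated time of 3 days (a lower number here means a stronger inhibitor, a higher number a weaker inhibitor), compound 3 is the only compound with an actual number. The other two sit at the limit of > 50000 nM in this assay, at which 2 of the 3 values shown sit.

Compound 4 `CCCN(CCC)CCCOc1c(-c2cc(OC)c(OC)c(OC)c2)oc2ccccc2c1=O` keeps the atoms of compound 3 but joins them differently: dipropylamino in place of 2-(diethylamino)ethyl on a saturated chain carbon, three bonds along the chain from an oxygen on an aromatic ring. Its dipropylamino group stands in place of 2-(diethylamino)ethyl, on a saturated chain carbon, three bonds along the chain from an oxygen on an aromatic ring.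

Among the measured compounds shown here, only two measured steps involve an amine-bearing chain: an at least 1.4-fold lower number from compound 1 to compound 3 (0.17 log units; that floor lies within the scatter) and an at least 1.4-fold lower number from compound 2 to compound 3 (0.17 log units; that floor lies within the scatter). Both are floors that lie within the scatter, and a step that the two limits leave unreadable from compound 1 to compound 2 cannot be read. None of them compares two amine-bearing chains, so no step beyond the scatter is expected in this assay, in either direction. The expected change is a 1.1-fold lower number from compound 3 to compound 4 (0.05 log units; within the scatter). For compound 4 the estimate is 30000 nM, with an expected range of 12000 nM to 50000 nM.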

Compound 4, half-maximal inhibitory concentration: > 50000 nM
Compound 4 ended at the assay's limit; the forecaster's own chance of this, stated with the estimate: 25%; middle value at least 1.6-fold (0.22 log units) from the limit.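

Among these compounds, the first comparison of two amine-bearing chains, with the same atoms joined differently, gives in this assay an at least 1.4-fold higher number from compound 3 to compound 4 (0.17 log units; that floor lies within the scatter), so the printed floor does not separate the two chains, although the true size of the step stays unknown. Compound 4 is a limit and not a number, which shows that an amine on this chain does not by itself yield a readable value, and it joins compound 1 and compound 2 at the same limit: the limit of > 50000 nM in this assay, at which 3 of the 4 values shown sit. The steps between compound 4 and compound 1 or compound 2 cannot be read, as both ends are limits.

What the compounds shown leave open is how a ring amine such as piperidine or morpholine, or a longer chain carrying diethylamino, would read. Among the compounds shown here, with compound 3 as the only number, no trend along the chain can yet be told.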